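Replacing Carboxy with Hydroxymethyl: Expected Effect on Cytotoxicity

The source may hold more compounds than are shown below. What is called first, only, known or untested is meant among the compounds shown, and "the series" means these compounds.

Compound 2 `O=C(O)c1cc(-c2ccc(F)nc2F)nn(Cc2ccc(Cl)cc2)c1=O` carries a carboxy group on its core. In an ADME assay on HepG2 2.2.15 cells (Homo sapiens) for cytotoxicity, read by MTT assay, with a stated time of 8 days (on this read-out lower numbers stand for higher toxicity in this test and higher numbers for lower toxicity in this test), compound 2 gives > 100000 nM, which is a limit of the assay rather than a measured number. Compound 1 `COCCNc1nc(F)c(-c2nn(Cc3ccc(C#N)cc3)c(=O)c3ccccc23)cc1Cl` likewise gives only a limit, > 100000 nM, in this assay. Going by the values given here, compound 3 `CN(C)CCNc1nc(F)c(-c2nn(Cc3ccc(C#N)cc3)c(=O)c3ccccc23)cc1Cl` is the one compound here with a number, giving 9760 nM in this assay. Among the compounds with values here, the only measured step, an at least 10-fold lower number from compound 1 to compound 3 (1.01 log units; beyond the scatter), concerns a dimethylamino group in place of methoxy on compounds that do not share the core of compound 2, so it speaks only loosely to the present question.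

Compound 4 `O=c1c(CO)cc(-c2ccc(F)nc2F)nn1Cc1ccc(Cl)cc1` differs from compound 2 in one place: hydroxymethyl in place of carboxy on an aromatic carbon. Within the data shown here, no measured step shows what such a swap does in this assay. What the three values do show is summed up by the limit of > 100000 nM in this assay, at which 2 of the 3 values shown sit: most compounds here sit at the limit, and compound 2 is one of them. For compound 4 the expected change in this assay is therefore a number no higher from compound 2 to compound 4 (the limit leaves the size open), no step beyond the scatter. Compound 4 is estimated to give about 100000 nM in this assay, within a range from 30000 nM to 300000 nM, most likely again as a limit.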

Compound 4, half-maximal cytotoxic concentration: > 100000 nM
Compound 4: no number, only a limit; the forecaster's own chance of this, stated with the estimate: 70%; the middle value lies on the limit itself.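

Going by these compounds alone, compound 2 and compound 4 each give only a limit in this assay, not a number, so no step between them can be read. What hydroxymethyl in place of carboxy on an aromatic carbon does in this test stays open, since most of the values shown stop at the same limit: the limit of > 100000 nM in this assay, at which 3 of the 4 values shown sit.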